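The source may hold more compounds than are shown below. What is called first, only, known or untested is meant among the compounds shown, and "the series" means these compounds.

Measured in an ADME assay (liver) for metabolic stability, with Liver microsome (Rattus norvegicus) as the target, using microsomes; a higher number here means faster removal of the compound, a lower number slower removal:
- Compound 1 `CN(C(=O)c1csc(-c2cccnc2)n1)c1ccc(OCc2ccc3ccccc3n2)cc1`: > 283 mL/min/kg, a limit.
- Compound 2 `CN(C(=O)c1ccncc1)c1ccc(OCc2ccc3ccccc3n2)cc1`: 15 mL/min/kg.

For the measured compounds named here, compound 2 holds the only exact number in this assay, since the other result is a limit. Compound 3 `CN(C(=O)c1cc(-c2ccccn2)n[nH]1)c1ccc(OCc2ccc3ccccc3n2)cc1` carries 3-(pyridin-2-yl)-1H-pyrazol-5-yl in place of pyridin-4-yl on a carbonyl carbon. Going by the values given here, one measured step bears on this place, and it is large and beyond the scatter: an at least 18-fold lower number from compound 1 to compound 2 (1.27 log units; beyond the scatter). The entering group resembles the 2-(pyridin-3-yl)-1,3-thiazol-4-yl of compound 1 more than it resembles pyridin-4-yl, as both join a five-membered aromatic ring to a six-membered aromatic ring. Part of that step is therefore expected to reverse, giving a higher number in this assay. The expected size is a 5.3-fold higher number from compound 2 to compound 3 (0.73 log units; beyond the scatter). For compound 3 the estimated clearance is 80 mL/min/kg, with an expected range of 25 mL/min/kg to 270 mL/min/kg.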

Compound 3, clearance: 35 mL/min/kg
Beside the measured number, compound 3's estimate is 2.3-fold (0.36 log units) above it; the measured number falls inside the stated range.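

In this assay, the place on the carbonyl carbon accepts a five-membered aromatic ring joined to a six-membered aromatic ring without the large earlier penalty returning in full, with an at least 8.0-fold lower number from compound 1 to compound 3 (0.90 log units; beyond the scatter). Against pyridin-4-yl, the larger 3-(pyridin-2-yl)-1H-pyrazol-5-yl still costs something, with a 2.3-fold higher number from compound 2 to compound 3 (0.37 log units; beyond the scatter), so the simple pyridin-4-yl keeps the lowest exact number so far. The gap to compound 1 has only one bound, as its result is a limit: the limit of > 283 mL/min/kg in this assay, at which 1 of the 3 values shown sits.

The entering and leaving groups of that last comparison differ in both rings, so the share of the five-membered ring and the share of the pyridine remain unseparated. Also open, as far as these compounds go, is how the number moves with a phenyl in place of the pyridin-2-yl, or with a methyl on the pyrazole nitrogen that carries the hydrogen.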